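This account rests on a few compounds, and the source may have more. Where it says the series, first, only, none or still open, it means among the compounds named here.

Of the compounds shown here, three have so far been measured in a functional assay on CHO cells for antagonist activity at prostaglandin E2 receptor EP1 subtype (Homo sapiens), read by FLIPR and calcium flux; on this read-out higher numbers stand for weaker inhibition and lower numbers for stronger inhibition. Compound 1, with the structure `CCc1ccccc1N(Cc1nnc(Cc2ccccc2)o1)S(=O)(=O)c1ccc(C)cc1`, gives 398 nM. Compound 2, `Cc1ccc(S(=O)(=O)N(Cc2nnc(Cc3c(Cl)cccc3Cl)o2)c2cccc(Cl)c2C)cc1`, gives 501 nM, a number that sits within the usual scatter of the value of compound 1, so the two cannot be told apart. Compound 3, `COc1ccc(Cc2nnc(CN(c3cccc(Cl)c3Cl)S(=O)(=O)c3ccc(Cl)cc3)o2)cc1`, gives 63.1 nM, a lower number that lies beyond the scatter when set against compound 1. Among the three numbers, compound 1 stands second highest.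

Compound 4, `CCc1ccccc1N(Cc1nnc(CNc2ccc(OC)cc2)o1)S(=O)(=O)c1ccc(C)cc1`, has not yet been measured. It differs from compound 1 in one place: (4-methoxyphenyl)amino in place of phenyl on a saturated chain carbon bound to an aromatic carbon. Within the data shown here, no measured pair shows this exact change by itself, so its direction has to be guessed. Compound 3 also carries a methoxy group on an aromatic ring, and compound 3 gives 63.1 nM, but compound 3 differs from compound 1 in other places as well, so the share of that ring in its number cannot be separated out. The change from compound 1 to compound 4 is therefore expected to be modest, with a slight lean toward a lower number, an expected step of a 1.3-fold lower number from compound 1 to compound 4 (0.12 log units; within the scatter). For compound 4 the estimated value is 300 nM, within a range from 80 nM to 1200 nM.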

Compound 4, inhibition constant: 794 nM
Compound 4: middle estimate off by 2.6-fold (0.42 log units), on the low side; the measured number falls inside the stated range.
By their numbers in this assay, from the lowest: compound 3; then compounds 1, 2 and 4 (each within the scatter of the next).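

In this assay, placing (4-methoxyphenyl)amino in place of phenyl on a saturated chain carbon bound to an aromatic carbon gives a 2.0-fold higher number from compound 1 to compound 4 (0.30 log units; within the scatter) and so the two compounds cannot be told apart. Among these compounds, this is the first direct look at this position, and it shows that a larger group, one that brings in a nitrogen, an oxygen and a hydrogen-bond donor while keeping a six-membered aromatic ring, leaves the read-out inside the normal spread of repeated measurements. Nothing available explains this outcome.

On these data alone, compound 4 brings in the amino nitrogen and the methoxy group together, so the share of each in its number stays unknown, and a single pair cannot show how this position responds to other groups. Plain phenylamino on the same saturated chain carbon would separate the nitrogen from the methoxy group, while a carboxylic acid in place of the methoxy group would test a quite different kind of substituent on that ring.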